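The compounds below may be only part of what the source reports. "The series", "measured", "known", "first", "only" and "open" are said of these compounds alone.

In a functional assay on HepG2 cells (Homo sapiens) for cytotoxicity, read by sulforhodamine B assay, with a stated time of 24 h (on this read-out higher numbers stand for weaker inhibition and lower numbers for stronger inhibition), compound 1 (`O=C1Nc2ccc(S(=O)(=O)N3CCOCC3)cc2/C1=N/c1cccc(C(F)(F)F)c1`) gives 14300 nM as its value, compound 2 (`N/N=C1\C(=O)Nc2ccc(S(=O)(=O)N3CCOCC3)cc21`) gives 32400 nM as its value and compound 3 (`O=C1Nc2ccc(S(=O)(=O)N3CCOCC3)cc2/C1=N/c1ccc(C(=O)O)cc1`) gives 23100 nM as its value. Compound 3 stands within the scatter of both others, with a 1.6-fold higher number from compound 1 to compound 3 (0.21 log units; within the scatter) and a 1.4-fold lower number from compound 2 to compound 3 (0.15 log units; within the scatter) as its two steps. Only a 2.3-fold higher number from compound 1 to compound 2 (0.36 log units; beyond the scatter) clears the scatter, and it is modest.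

Compound 4 (`CC(=O)c1cccc(/N=C2\C(=O)Nc3ccc(S(=O)(=O)N4CCOCC4)cc32)c1`) is still unmeasured, and its difference from compound 3 is 3-acetylphenyl in place of 4-carboxyphenyl on a double-bonded nitrogen at this one place. The change puts 3-acetylphenyl in place of 4-carboxyphenyl on a double-bonded nitrogen. Going by the values given here, the closest precedent is the exchange of one substituted phenyl for another at that place, seen in a 1.6-fold higher number from compound 1 to compound 3 (0.21 log units; within the scatter) and within the scatter. The step of a 2.3-fold higher number from compound 1 to compound 2 (0.36 log units; beyond the scatter) removes the phenyl altogether and so bears less directly. Among the compounds with values here, no measured compound carries 3-acetylphenyl, so this expectation rests on few data.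

In this assay no step beyond the scatter is expected, in either direction. The expected step is a 1.3-fold lower number from compound 3 to compound 4 (0.11 log units; within the scatter) and it is estimated to stay within the scatter. For compound 4 the estimated value is 18000 nM with an expected range from 10000 nM to 32000 nM as its upper end.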

Compound 4, half-maximal inhibitory concentration: 28600 nM
Estimate against measurement, compound 4: 1.6-fold (0.20 log units) below, and the stated range covers the measured number.
By their numbers in this assay, from the lowest: compounds 1, 3, 4 and 2 (each within the scatter of the next, the first and the last beyond it).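

In this assay, 3-acetylphenyl in place of 4-carboxyphenyl on the double-bonded nitrogen gives a 1.2-fold higher number from compound 3 to compound 4 (0.09 log units; within the scatter), so this exchange stays within the scatter even though the entering group carries 0 hydrogen-bond donors and the leaving group carries 1. The other two new steps, a 1.1-fold lower number from compound 2 to compound 4 (0.05 log units; within the scatter) and a 2.0-fold higher number from compound 1 to compound 4 (0.30 log units; within the scatter), also stay within the scatter; the second of these is acetyl in place of trifluoromethyl on an aromatic carbon, and the first shows that compound 4, although it keeps a substituted phenyl at this place, cannot be told apart from the amino compound 2, so the separation of compound 1 from compound 2 does not extend to all the substituted phenyl groups here. Nothing available explains why these groups give such closely spaced read-outs.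

Still open, on these data alone, is whether a nitrile, a primary amine or a longer chain on the aromatic ring in place of acetyl would give a step beyond the scatter. Also open, as far as these compounds go, is whether replacing the sulfonyl-bearing part of the shared core would move the read-out more than any change at the double-bonded nitrogen.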